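From Trifluoromethyl to Methoxy in a Growth Inhibitor Pair

This account rests on a few compounds, and the source may have more. Where it says the series, first, only, none or still open, it means among the compounds named here.

Going by the values given here, in a functional assay on T47D cells (Homo sapiens) for inhibition, read by CCK-8 assay, with a stated time of 72 h, tested at 10 uM (a lower number here means less inhibition of growth, a higher number more inhibition of growth at the concentration tested), compound 1 `CN(C)C(=O)c1cc2cnc(Nc3ccc(NC(=O)C4(C(=O)Nc5ccc(Cl)c(C(F)(F)F)c5)CC4)cc3)nc2n1C1CCCC1` gives 55.8%, while compound 2 `CN(C)C(=O)c1cc2cnc(Nc3ccc(NC(=O)C4(C(=O)Nc5cccc(C(F)(F)F)c5)CC4)cc3)nc2n1C1CCCC1` gives 92.7%, the higher of the two numbers so far. Among the compounds with values here, the single measured step, hydrogen in place of chloro on an aromatic carbon, gives a number 36.9 percentage points higher from compound 1 to compound 2 (beyond the scatter), which is large and beyond the scatter. Compound 3 `COc1cccc(NC(=O)C2(C(=O)Nc3ccc(Nc4ncc5cc(C(=O)N(C)C)n(C6CCCC6)c5n4)cc3)CC2)c1` differs from compound 2 by methoxy in place of trifluoromethyl on an aromatic carbon, meta to a large group: methoxy in place of trifluoromethyl on an aromatic carbon. The measured step concerns a different group, so it bears only indirectly, showing that one small change can move this read-out widely. With compound 2 at 92.7% little room remains upward, so a moderate fall in this assay is expected, smaller than the measured step. The estimated step is a number 16.7 percentage points lower from compound 2 to compound 3 (beyond the scatter). Compound 3 is estimated at 76%, with a range of 50% to 95%.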

Compound 3, percent growth inhibition at one concentration: 93.5%
For compound 3 the middle estimate is 17.5 percentage points below the measured one; the range from low to high includes it.
By their numbers in this assay, from the lowest: compound 1; then compounds 2 and 3 (each within the scatter of the next).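

In this assay, methoxy in place of trifluoromethyl on an aromatic carbon, meta to a large group, gives a number 0.8 percentage points higher from compound 2 to compound 3 (within the scatter), so this read-out does not separate the two groups at this position, although they differ in heavy atoms and in hydrogen-bond acceptors. With 3-methoxyphenyl in place of 4-chloro-3-(trifluoromethyl)phenyl on an amide-type nitrogen, the result is a number 37.7 percentage points higher from compound 1 to compound 3 (beyond the scatter), and among these three compounds only compound 1, the one carrying chloro, stands apart. Nothing available here explains either result.

From the compounds shown here alone, compound 2 and compound 3 are compared at one concentration only, so whether they would also match at a lower concentration remains open. Going by these compounds, it is also open whether an amine or a carboxylic acid at this position would keep the number this high.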